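The source may report more compounds than this note shows. Statements on the series, on what has been measured and on what is new or still open speak of the compounds shown alone.

Compound 1 (`COc1ccc(/C=C/C(=O)c2cccc(Br)c2)cc1OC`) offers no starting number, since in a functional assay on CNE-2 cells (Homo sapiens) for cytotoxicity, read by sulforhodamine B assay, with a stated time of 48 h (a lower number here means a stronger inhibitor, a higher number a weaker inhibitor), compound 1 is recorded as "not determined" (no result reported) and so has no place on the scale. Compound 3 (`COc1ccc(/C=C/C(=O)c2cccc(Br)c2)cc1`) is no help, because compound 3 is likewise recorded as "not determined" (no result reported) in this assay without a result. Only compound 2 (`COc1ccc(-c2cc(C(=O)/C=C/c3cc(OC)c(OC)c(OC)c3)ccc2N)cc1OC`) has a figure, with compound 2 at 4330 nM in this test. Compound 4 (`COc1ccc(/C=C/C(=O)c2cccc(-c3cccc(F)c3)c2)cc1OC`) differs from compound 1 by one change, (3-fluorophenyl in place of bromo on an aromatic carbon), which puts 3-fluorophenyl in place of bromo on an aromatic carbon. Within the data shown here, with no measured pair to compare, neither the size nor the direction of this step can be predicted with confidence. Compound 2 also carries an added aromatic ring, so its 4330 nM serves as a rough guide. Compound 4 is estimated at 8000 nM, with an expected range from 2000 nM to 30000 nM in this test.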

Compound 4, half-maximal inhibitory concentration: 770 nM
The estimate for compound 4 lay 10-fold (1.02 log units) above the measured number; the measured number lies below the stated range.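

Among these compounds, compound 1 stands at "not determined" (no result reported) so no step from it to compound 4 can be read. What placing 3-fluorophenyl in place of bromo does to potency stays open, and no evidence shown explains the result for compound 4.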